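The compounds below may be only part of what the source reports. "The series", "measured", "known", "first", "only" and "open" are said of these compounds alone.

Measured compounds:
- compound 1, `Fc1ccc2nc(Nc3nc4ccccc4s3)sc2c1`
- compound 2, `c1ccc2sc(Nc3nc4ccccc4s3)nc2c1`

Compound 1 shows only a limit of the assay in a functional assay on THP-1 cells (Homo sapiens) for cytotoxicity, read by MTT assay, with a stated time of 48 h (on this read-out higher numbers stand for weaker inhibition and lower numbers for stronger inhibition), > 50000 nM; > 50000 nM (2 entries) in both of its two entries, and no number. Among the compounds with values here, compound 2 is the only compound in the set with a measured number: in this assay compound 2 gives 28800 nM, so it is the sole point of reference for the series, and the further entry for compound 1 adds no number to compare against.

Compound 3, `Cc1ccc2nc(Nc3nc4ccccc4s3)sc2c1`, has not been measured. It differs from compound 2 in one place: methyl in place of hydrogen on an aromatic carbon. Within the data shown here, no step between two measured compounds is recorded for this series, so there is no prior step of this kind to lean on. The expected size of the step in this assay is therefore small, with no direction that can be argued from the data, and most likely within the usual scatter of repeated measurements. The step from compound 2 to compound 3 is estimated at a 1.1-fold lower number from compound 2 to compound 3 (0.04 log units; within the scatter), essentially flat. Compound 3 is expected to give about 26000 nM in this assay, within a range of 9000 nM to 75000 nM; the chance that only a limit is reported is not negligible given how close the reference value of compound 2 sits to that limit.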

Compound 3, half-maximal inhibitory concentration: 34200 nM
Compound 3: the middle estimate sits 1.3-fold (0.12 log units) below what was measured; the range from low to high includes it.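

Within the data shown here, the one readable step in this assay is a 1.2-fold higher number from compound 2 to compound 3 (0.07 log units; within the scatter) and it stands for methyl in place of hydrogen on an aromatic carbon, meta to a fused ring and para to a fused ring. The read-out therefore does not separate the two compounds, and this position on the six-membered aromatic ring accepts a single added carbon with no step beyond the scatter. Nothing measured alongside these values speaks to the reason for this result.

Compound 1, which carries fluorine on the same aromatic carbon, gives > 50000 nM; > 50000 nM (2 entries) in this assay and this is a limit of the assay, not a number, so fluorine in this place cannot be set against hydrogen or methyl as a step. As far as these compounds go, whether an amine, a carboxylic acid or a longer chain such as ethyl on this carbon would move the value beyond the scatter remains open, as does the effect of the same methyl on other carbons of the core.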